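The source may hold more compounds than are shown below. What is called first, only, known or untested is meant among the compounds shown, and "the series" means these compounds.

Of the compounds shown here, three with a shared core have been measured in a functional assay on OVCAR-8 cells (Homo sapiens) for antiproliferative activity; a higher number here means a weaker inhibitor, a lower number a stronger inhibitor. Compound 1 `Cn1ncc(Cl)c1-c1cc(C(=O)N[C@@H]2CN[C@H](CCNS(C)(=O)=O)C[C@H]2c2ccc(F)c(F)c2)oc1Cl` gives 1530 nM, and compound 2 `Cn1ncc(Cl)c1-c1cc(C(=O)N[C@@H]2CN[C@H](CC(O)CO)C[C@H]2c2ccc(F)c(F)c2)oc1Cl` gives 690 nM. Compound 3 `Cn1ncc(Cl)c1-c1cc(C(=O)N[C@@H]2CN[C@H](CCN3CCC(O)CC3)C[C@H]2c2ccc(Cl)c(Cl)c2)oc1Cl` gives 15900 nM, the highest number of the three and beyond the scatter from both others.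

Compound 4 `C=CC[C@@H]1C[C@@H](c2ccc(Cl)c(Cl)c2)[C@H](NC(=O)c2cc(-c3c(Cl)cnn3C)c(Cl)o2)CN1` differs from compound 3 in one place: vinyl in place of (4-hydroxypiperidin-1-yl)methyl on a saturated chain carbon bound to a saturated ring carbon. The 4-hydroxypiperidin-1-yl ring is lost, and the chain now ends in vinyl.

Going by the values given here, only one measured step involves a change at this place: a 2.2-fold lower number from compound 1 to compound 2 (0.35 log units; beyond the scatter). That step is modest, but it is a weak guide, since neither of its compounds has vinyl on the chain. Compound 1 and compound 2 also differ from compound 3 in more than the chain, so their lower values cannot be credited to the chain alone. Even so, compound 3 at 15900 nM stands at the top of this small set, so a move toward a lower number seems more likely than a further rise.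

The expected change is a 5.3-fold lower number from compound 3 to compound 4 (0.72 log units; beyond the scatter). For compound 4 the estimated value is 3000 nM, with an expected range of 700 nM to 12000 nM.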

Compound 4, half-maximal inhibitory concentration: 990 nM
Beside the measured number, compound 4's estimate is 3.0-fold (0.48 log units) above it; the range from low to high includes it.
By their numbers in this assay, from the lowest: compounds 2, 4 and 1 (each within the scatter of the next, the first and the last beyond it); then compound 3.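

In this assay, going by these compounds alone, the change at this position gives a 16-fold lower number from compound 3 to compound 4 (1.21 log units; beyond the scatter) as a large step, whereas the only earlier step at this place, a 2.2-fold lower number from compound 1 to compound 2 (0.35 log units; beyond the scatter), was modest. The position therefore does not need the ring: the group that leaves has 8 heavy atoms, 1 hydrogen-bond donor and 2 hydrogen-bond acceptors, the vinyl that enters has 2 heavy atoms and neither donors nor acceptors, and the number still falls. No measurement here explains why the number falls so far.

On these data alone, it remains open whether the drop comes from losing the 4-hydroxypiperidin-1-yl ring or from gaining the vinyl. A saturated propyl chain or a chain ending in a primary amine, each on the core of compound 4, would help separate these two readings.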